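Thioamide in place of nitrile on the shared core

A few compounds are considered here, and "the series" means these few. Any claim that something is new, unique, unknown or untested is made for them only; others in the source may bear on it.

Measured so far in a functional assay on KB cells (Homo sapiens) for cytotoxicity; on this read-out lower numbers stand for stronger inhibition and higher numbers for weaker inhibition:
Compound 1 `C=CCn1cc(C(N)=S)c2c(N)ncnc21` gives 19000 nM.
Compound 2 `NC(=S)c1cn(COC(CO)CO)c2ncnc(N)c12` gives only a limit, > 100000 nM.
Compound 3 `N#Cc1cn(Cc2ccccc2)c2ncnc(N)c12` gives only a limit, > 100000 nM.

Compound 3 sits at the limit of > 100000 nM in this assay, at which 2 of the 3 values shown sit. Compound 4 `NC(=S)c1cn(Cc2ccccc2)c2ncnc(N)c12` differs from compound 3 by a group of 3 heavy atoms (1 carbon, 1 nitrogen, 1 sulfur; no ring) in place of a group of 2 heavy atoms (1 carbon, 1 nitrogen; no ring), on an aromatic carbon. Among the compounds with values here, no measured step covers this exchange: the single measured step, an at least 5.2-fold higher number from compound 1 to compound 2 (0.72 log units; beyond the scatter), keeps the thioamide and changes only the group on the saturated chain carbon bound to the aromatic nitrogen, so it says nothing about the group that enters here. Compounds 1 and 2 both carry that entering group, one with a number and one with a limit, so the group alone does not decide the outcome. The starting point for compound 3 is a limit, so the expected direction for an at least 2.5-fold lower number from compound 3 to compound 4 (0.39 log units; beyond the scatter) is toward a smaller number, estimated with low confidence. Compound 4 is expected to give about 40000 nM, with a range from 8000 nM to 150000 nM.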

Compound 4, half-maximal inhibitory concentration: 32000 nM
The estimate for compound 4 lay 1.3-fold (0.10 log units) above the measured number; the measured number falls inside the stated range.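

Thioamide in place of nitrile on the aromatic carbon of the five-membered ring brings an at least 3.1-fold lower number from compound 3 to compound 4 (0.49 log units; beyond the scatter) in this assay, the first step that reads this position directly. Compound 3 gives only a limit in this assay: the limit of > 100000 nM in this assay, at which 2 of the 4 values shown sit. With the thioamide kept, phenyl in place of 2-hydroxy-1-(hydroxymethyl)ethoxy on the saturated chain carbon brings an at least 3.1-fold lower number from compound 2 to compound 4 (0.49 log units; beyond the scatter), while phenyl in place of vinyl gives a 1.7-fold higher number from compound 1 to compound 4 (0.23 log units; within the scatter), so the group on that chain carbon separates compound 2 from compound 1 and compound 4, which lie within the scatter of each other.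

Going by these compounds, only one nitrile stands, so whether the exchange reads the same with the other chains stays open. Also open, on these data alone, is how a carboxylic acid or a primary amide would read on the same aromatic carbon.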